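Changing the Ring on the Sulfonyl Sulfur of Compound 1

The compounds below may be only part of what the source reports. "The series", "measured", "known", "first", "only" and "open" are said of these compounds alone.

Among the measured compounds shown here, compound 1 `O=S(=O)(c1ccc(F)c(F)c1)c1cnc2c(F)cccc2c1-c1ccc(Cl)cc1` gives 0.28 mL/min in an ADME assay on microsomes from liver (Homo sapiens) for metabolic stability, tested at 2.5 uM (on this read-out lower numbers stand for slow clearance and higher numbers for fast clearance), the lowest of the two numbers measured so far. For the measured compounds named here, compound 2 `O=S(=O)(c1ccc(F)c(F)c1)c1cnc2c(F)cccc2c1-c1cccc(Cl)c1` gives 1.13 mL/min in this assay, and the only measured step, a 4.0-fold higher number from compound 1 to compound 2 (0.61 log units; beyond the scatter), alters the chlorophenyl ring rather than the ring on the sulfonyl sulfur. Compound 3 `N#Cc1cccc(S(=O)(=O)c2cnc3c(F)cccc3c2-c2ccc(Cl)cc2)c1` differs from compound 1 by 3-cyanophenyl in place of 3,4-difluorophenyl on a sulfonyl sulfur. Going by the values given here, no measured step bears on this position, so the data give no direction. For compound 3 a step within the scatter is expected, a 1.3-fold higher number from compound 1 to compound 3 (0.10 log units; within the scatter). Compound 3 is therefore estimated at 0.35 mL/min, with a range from 0.15 mL/min to 0.9 mL/min.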

Compound 3, intrinsic clearance in a liver preparation (reported as CLH), per the amount of preparation that the assay uses: 0.08 mL/min
Compound 3: middle estimate off by 4.4-fold (0.64 log units), on the high side; the measured number lies below the stated range.
By their numbers in this assay, from the lowest: compound 3; then compound 1; then compound 2.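

In this assay the ring on the sulfonyl sulfur proves to be a position that matters: 3-cyanophenyl in place of 3,4-difluorophenyl gives a 3.5-fold lower number from compound 1 to compound 3 (0.54 log units; beyond the scatter) and moves the number towards slow clearance. No measurement at hand explains why this ring gives the lower number.

Whether the nitrile or the loss of the two fluorines accounts for the step stays open, with only this one replacement shown. Also open, from the compounds shown here alone, are how an amine or a morpholine ring on the sulfonyl sulfur would behave, and whether the same step holds with the 3-chlorophenyl ring of compound 2.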